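The compounds below may be only part of what the source reports. "The series", "measured", "known", "first", "only" and "open" are said of these compounds alone.

Of the compounds shown here, three built on one shared core have been tested in a functional assay on the whole organism with Rattus norvegicus as the target, with a stated time of 4 h, at a dose of 40 mg/kg by the intraperitoneal route; a higher number here means more inhibition at the dose given (going by the name of the read-out), a lower number less inhibition. Compound 1 `Cc1nc2c(C[S+]([O-])c3ccccc3)cccn2c1C` gives 42%. Compound 2 `Cc1nc2c(OCc3ccccc3)cccn2c1C(N)=O` gives 42%. Compound 3 `CC(=O)c1c(C)nc2c(OCc3ccccc3)cccn12` gives 57%, the highest of the three; both compound 1 and compound 2 stand beyond the scatter below it. Among the measured compounds shown here, the only measured step that changes one place is a number 15 percentage points higher from compound 2 to compound 3 (beyond the scatter), a modest rise.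

Compound 4 `Cc1nc2c(OCc3ccccc3)cccn2c1CCC#N` has not yet been measured. It differs from compound 3 in one place: 2-cyanoethyl in place of acetyl on an aromatic carbon. For the measured compounds named here, no measured step swaps an acetyl for a 2-cyanoethyl, and no measured step involves a nitrile at all, so the direction of this change is an open question. The one point of reference is that the rise in this assay came with a methyl in place of an amino group on the carbonyl carbon, and the carbonyl itself now leaves. The expected step is a number 12 percentage points lower from compound 3 to compound 4 (beyond the scatter), a modest fall back toward the values of compound 1 and compound 2. Compound 4 is therefore estimated to give about 45%, within 25% to 65%.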

Compound 4, a percentage reported as inhibition, in the whole organism at one dose (the size of the read-out at that dose, not a potency): 40%
For compound 4 the middle estimate is 5 percentage points above the measured one, and the stated range covers the measured number.
By their numbers in this assay, from the lowest: compounds 4, 1 and 2 (each within the scatter of the next); then compound 3.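

Putting 2-cyanoethyl in place of acetyl on this aromatic carbon gives a number 17 percentage points lower from compound 3 to compound 4 (beyond the scatter) in this assay, so acetyl now stands above two different groups at this position rather than one. Set against the carbamoyl group, 2-cyanoethyl gives a number 2 percentage points lower from compound 2 to compound 4 (within the scatter), so at this dose the two groups cannot be told apart, although one has a carbonyl and the other a nitrile. No measurement here explains why acetyl stands apart from them.

The compounds shown leave open whether the higher number depends on the whole acetyl group or on some part of it, a question that a propanoyl group, a carboxylic acid or a plain ethyl chain on the same carbon could help to answer. They also leave open whether this order would hold at other doses or at other times.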